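A few compounds are considered here, and "the series" means these few. Any claim that something is new, unique, unknown or untested is made for them only; others in the source may bear on it.

Series notes. In an ADME assay on microsomes from liver (Homo sapiens), read by LC-MS, using NADPH, with a stated time of 30 min, tested at 1 uM (on this read-out higher numbers stand for a more stable compound and lower numbers for a less stable compound), compound 1 `C[C@H](Nc1ncnc2[nH]cnc12)c1cc2ccc(F)cn2c(=O)c1-c1ccccc1` gives 98%, compound 2 `C[C@H](Nc1nc(N)ncc1C#N)c1cc2ccc(F)cn2c(=O)c1-c1ccccc1` gives 90%, and compound 3 `Cc1nc(N)nc(N[C@@H](C)c2cc3ccc(F)cn3c(=O)c2-c2ccccc2)c1C#N` gives 83%. Compound 3 holds the lowest of the three numbers, though its gap to compound 2 lies within the scatter, while the step of a number 15 percentage points lower from compound 1 to compound 3 (beyond the scatter) lies beyond it. Compound 4 `Cc1nc(N)nc(N[C@@H](C)c2c(-c3ccccc3)c(=O)n3cc(F)ccc3c2C)c1C#N` differs from compound 3 by methyl in place of hydrogen on an aromatic carbon, placed ortho to a fused ring and two atoms from the ring nitrogen. For the measured compounds named here, the one measured step of the same kind, methyl in place of hydrogen on an aromatic carbon, is a number 7 percentage points lower from compound 2 to compound 3 (within the scatter), within the scatter, and it concerns a different ring, so it bears only loosely. No step beyond the scatter is therefore expected in this assay; the expected step is a number 5 percentage points lower from compound 3 to compound 4 (within the scatter). Compound 4 is estimated at 78%, within 60% to 92%.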

Compound 4, percent of the compound remaining: 96%
Estimate against measurement, compound 4: 18 percentage points below, outside the stated range (above it).
By their numbers in this assay, from the lowest: compounds 3, 2, 4 and 1 (each within the scatter of the next, the first and the last beyond it).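

In this assay, for the compounds shown here, methyl in place of hydrogen on this aromatic carbon, ortho to a fused ring and two atoms from the ring nitrogen, gives a number 13 percentage points higher from compound 3 to compound 4 (beyond the scatter) and is the first methyl step here beyond the scatter. The earlier methyl step, a number 7 percentage points lower from compound 2 to compound 3 (within the scatter) on a different ring, lies within the scatter and did not show this position's response. No measurement at hand accounts for the rise.

Going by these compounds, an ethyl, a methoxy or a chlorine on this carbon remains open. So does whether methyl here gives a similar step with the amine substituent of compound 1.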